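A few compounds are considered here, and "the series" means these few. Any claim that something is new, unique, unknown or untested is made for them only; others in the source may bear on it.

In a toxicity assay on MDCK cells (Canis lupus familiaris) for cytotoxicity, read by crystal violet staining, with a stated time of 48 h (on this read-out lower numbers stand for higher toxicity in this test and higher numbers for lower toxicity in this test), the three measured compounds share one core and differ only in what is carried on one amine nitrogen. Compound 1 `Cc1ccc2[nH]c(=O)c(CN(CCCO)Cc3ccc(C(C)(C)C)cc3)cc2c1` gives > 10000 nM in this assay, which is a limit of the assay and not a number. Compound 2 `Cc1ccc2[nH]c(=O)c(CN(Cc3ccc(OC(F)(F)F)cc3)Cc3ccc(C(C)(C)C)cc3)cc2c1` gives > 5000 nM in this assay, again a limit. Compound 3 `Cc1ccc2[nH]c(=O)c(CN(Cc3ccc(C(C)(C)C)cc3)[C@H](CO)c3ccccc3)cc2c1` gives > 10000 nM in this assay, a limit as well. Two limits occur among the measured values: the limit of > 10000 nM in this assay, at which 2 of the 3 values shown sit, and (the limit of > 5000 nM in this assay, at which 1 of the 3 values shown sits). Every measured value is a limit. The steps a step that the two limits leave unreadable from compound 1 to compound 2, a step that the two limits leave unreadable from compound 1 to compound 3 and a step that the two limits leave unreadable from compound 2 to compound 3 all stay unreadable in size, and compound 3 stands where it cannot be ranked against compound 1 or compound 2 on these numbers. Compound 4 `Cc1ccc2[nH]c(=O)c(CN(Cc3ccc(C(C)(C)C)cc3)C(C)c3ccc(F)cc3)cc2c1` differs from compound 3 by 1-(4-fluorophenyl)ethyl in place of 2-hydroxy-1-phenylethyl on an amine nitrogen. Going by the values given here, no measured step bears readably on this change, and nothing among the three measured compounds shows a readable move away from a limit. Compound 4 is therefore expected to sit again at the limit, an expected step of a number no higher from compound 3 to compound 4 (the limit leaves the size open) that is not taken as a change beyond the scatter. Compound 4 is estimated at 10000 nM, within 5000 nM to 30000 nM, most likely reported once more only as a limit.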

Compound 4, half-maximal cytotoxic concentration: > 33000 nM
Compound 4: a limit, no number (the forecaster's own chance of this, stated with the estimate: 80%); at least 3.3-fold (0.51 log units) between middle value and limit.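

In this assay compound 4 gives only a limit and not a number, as do compound 1, compound 2 and compound 3, so the steps to compound 4 from these three cannot be read in size. The compounds shown leave open whether any group carried on the amine nitrogen changes the half-maximal cytotoxic concentration at all.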